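Swapping 3-methoxyphenyl for 4-nitrophenyl in compound 1

The compounds below may be only part of what the source reports. "The series", "measured", "known", "first", "only" and "open" are said of these compounds alone.

Going by the values given here, in a functional assay on HeLa cells (Homo sapiens) for cytotoxicity, read by WST assay, with a stated time of 48 h (on this read-out higher numbers stand for weaker inhibition and lower numbers for stronger inhibition), compound 1 (`COc1cccc(/C=C/C[C@H]2C[C@@H]([C@@H](O)c3ccccc3)CO[C@@H]2c2ccccc2)c1`) gives 10900 nM, the lowest of the three numbers measured so far. Compound 2 (`C=CC[C@H]1C[C@@H]([C@@H](O)c2ccccc2)CO[C@@H]1c1ccccc1`) gives 25400 nM, and compound 3 (`COc1ccc(CCC[C@@H]2C[C@@H]([C@@H](O)c3ccc(OC)c(OC)c3)CO[C@H]2c2ccc(OC)c(OC)c2)cc1OC`) gives 35700 nM. Compound 4 (`O=[N+]([O-])c1ccc(/C=C/C[C@H]2C[C@@H]([C@@H](O)c3ccccc3)CO[C@@H]2c2ccccc2)cc1`) has not yet been measured. It departs from compound 1 in one place, with 4-nitrophenyl in place of 3-methoxyphenyl on a double-bonded chain carbon bound to a double-bonded chain carbon.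

Among the compounds with values here, only one measured step bears on this change. Putting vinyl in place of the whole 2-(3-methoxyphenyl)ethenyl gives a 2.3-fold higher number from compound 1 to compound 2 (0.37 log units; beyond the scatter), a modest step even though the entire aromatic ring is lost. Compound 3 differs from compound 1 in several places, so it offers no direct reading. Within the data shown here, no measured compound shows what changing the group on that ring does by itself, and none carries a nitro group. A swap that keeps the ring is therefore expected to move the number in this assay by less than the step to compound 2, with no step beyond the scatter and no firm direction. The expected step is a 1.1-fold lower number from compound 1 to compound 4 (0.04 log units; within the scatter). For compound 4 the estimated value is 10000 nM, with an expected range from 4000 nM to 25000 nM.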

Compound 4, half-maximal inhibitory concentration: 12400 nM
The estimate for compound 4 lay 1.2-fold (0.09 log units) below the measured number; low and high end bracket the measured number.
By their numbers in this assay, from the lowest: compounds 1 and 4 (each within the scatter of the next); then compounds 2 and 3 (each within the scatter of the next).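

In this assay, 4-nitrophenyl in place of 3-methoxyphenyl on a double-bonded chain carbon bound to a double-bonded chain carbon gives a 1.1-fold higher number from compound 1 to compound 4 (0.06 log units; within the scatter), so the two aryl groups cannot be told apart at this position in this read-out. The earlier compounds had shown only the removal of the whole 2-(3-methoxyphenyl)ethenyl group, a 2.3-fold higher number from compound 1 to compound 2 (0.37 log units; beyond the scatter), and this pair adds that a methoxy-bearing ring and a nitro-bearing ring can be exchanged there with the step staying within the scatter. No measurement available here explains why these two groups read alike.

The swap changes both the group on the ring and the number in its name, so the compounds shown cannot separate the two changes, and 4-methoxyphenyl or 3-nitrophenyl would be needed to do so. They also leave open whether this tolerance extends to a ring carrying a carboxylic acid or an amine, or to a plain phenyl ring with no group on it at all.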